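This account rests on a few compounds, and the source may have more. Where it says the series, first, only, none or still open, it means among the compounds named here.

In a functional assay with Oryctolagus cuniculus as the target (on this read-out higher numbers stand for weaker inhibition and lower numbers for stronger inhibition), compound 1 `C/N=C(/NC)Nc1nc(-c2ccc(OC)cc2)c(-c2ccc(OC)cc2)s1` gives 970 nM. Compound 2 `COc1ccc(-c2nc(CNC(=O)CSC)sc2-c2ccc(OC)cc2)cc1` reads < 100 nM, which is a limit. Compound 3 `COc1ccc(-c2nc(C(=O)N3CCOCC3)sc2-c2ccc(OC)cc2)cc1` reads < 10 nM, also a limit and not a number. Compound 4 `COc1ccc(-c2nc(C3=CCN(C)CC3)sc2-c2ccc(OC)cc2)cc1` loses the (morpholin-4-yl)carbonyl of compound 3 on the same aromatic carbon: a group of 7 heavy atoms (6 carbon, 1 nitrogen; one six-membered non-aromatic ring with 1 hetero atom) in place of a group of 8 heavy atoms (5 carbon, 1 nitrogen, 2 oxygen; one six-membered non-aromatic ring with 2 hetero atoms), on an aromatic carbon. Two steps at this carbon bear on the change, an at least 9.7-fold lower number from compound 1 to compound 2 (0.98 log units; beyond the scatter) and an at least 97-fold lower number from compound 1 to compound 3 (1.98 log units; beyond the scatter), and both lie beyond the scatter, whereas a step that the two limits leave unreadable from compound 2 to compound 3 cannot be sized. Compound 4 keeps a six-membered non-aromatic ring, which the group in compound 1 lacks, so a return to the level of this assay seen there is not expected. The expected change is modest and upward, an at least 3.0-fold higher number from compound 3 to compound 4 (0.47 log units; beyond the scatter). For compound 4 the estimated value is 30 nM, with an expected range from 3 nM to 300 nM.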

Compound 4, half-maximal inhibitory concentration: < 10 nM
Compound 4 gave a limit, no number; the forecaster's own chance of this, stated with the estimate: 45%; middle value at least 3.0-fold (0.47 log units) from the limit.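

Compound 4 shows that this aromatic carbon, next to the ring nitrogen and next to the ring sulfur, can carry a ring with 1 hetero atom and no carbonyl and still stay far from compound 1: an at least 97-fold lower number from compound 1 to compound 4 (1.98 log units; beyond the scatter). The steps to compound 4 from compound 2 and from compound 3 cannot be read, and compound 4 gives only a limit, the same as compound 3: the limit of < 10 nM in this assay, at which 2 of the 4 values shown sit.

The compounds shown leave open whether the change from compound 3 to compound 4 moves the number at all. They also leave open whether a carboxylic acid or a dimethylamino group on this carbon, with no ring, would hold that level.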